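From Phenoxy to Sulfanyl on a Shared Diamino Core

A few compounds are considered here, and "the series" means these few. Any claim that something is new, unique, unknown or untested is made for them only; others in the source may bear on it.

Compound 1, with the structure `Nc1cc(N)c2nc(-c3ccccc3)c(Oc3ccc(Cl)c(Cl)c3)nc2c1`, was tested in a functional assay on T47D cells (Homo sapiens) for inhibition, read by sulforhodamine B assay, with a stated time of 48 h (on this read-out lower numbers stand for stronger inhibition of growth and higher numbers for weaker inhibition of growth), and gives 24500 nM. Among the three measured compounds its number is the second highest, but the two others sit within the usual scatter of it: compound 2, `Nc1cc(N)c2nc(-c3ccccc3)c(NCc3ccc(Cl)c(Cl)c3)nc2c1`, gives 19500 nM, and compound 3, `CCOC(=O)[C@H](CCC(=O)O)NC(=O)c1ccc(Sc2nc3cc(N)cc(N)c3nc2-c2ccccc2)cc1`, gives 28800 nM. Compound 3 already carries a sulfur link between the core and an aromatic ring, and its number is close to that of compound 1.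

Compound 4, `Nc1cc(N)c2nc(-c3ccccc3)c(Sc3ccc(Cl)c(Cl)c3)nc2c1`, has not been measured. It differs from compound 1 in one place: (3,4-dichlorophenyl)sulfanyl in place of 3,4-dichlorophenoxy on an aromatic carbon. Among the measured compounds shown here, no pair of measured compounds differing only in this way exists, so the size of the step has to be guessed. The closeness of compound 3 to compound 1 suggests little effect from the linker change, so the expected step from compound 1 to compound 4, a 1.0-fold higher number from compound 1 to compound 4 (0.01 log units; within the scatter), is none beyond the scatter. Compound 4 is expected to give about 25000 nM in this assay, within a range from 10000 nM to 60000 nM.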

Compound 4, concentration for 50% growth inhibition: 13200 nM
Beside the measured number, compound 4's estimate is 1.9-fold (0.28 log units) above it; low and high end bracket the measured number.
By their numbers in this assay, from the lowest: compounds 4, 2, 1 and 3 (each within the scatter of the next, the first and the last beyond it).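

Among the compounds shown here, this is the first pair in the set that differs only at this position, so the effect of the linking atom can be read directly instead of being inferred from less closely related compounds. Placing (3,4-dichlorophenyl)sulfanyl in place of 3,4-dichlorophenoxy on this aromatic carbon gives a 1.9-fold lower number from compound 1 to compound 4 (0.27 log units; within the scatter) in this assay, so at this level of precision the sulfur and oxygen links cannot be told apart on this shared core. No accompanying measurement offers an explanation for this step.

Going by these compounds, whether a sulfonyl link at the same carbon would give a clearly different number remains open. It is also unknown how the sulfur-linked compound would respond if a methoxy group or a carboxylic acid replaced the two chlorines on its outer ring.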